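Methoxy for chloro on the oxime aryl of compound 3

The source may hold more compounds than are shown below. What is called first, only, known or untested is meant among the compounds shown, and "the series" means these compounds.

Measured compounds:
compound 1 `COc1ccc(/C=C/C(=N\O)c2ccc(OC)cc2)cc1` — 2170000 nM
compound 2 `O/N=C(\C=C\c1ccc(Cl)cc1)c1ccc(Cl)cc1` — 14100 nM
compound 3 `O/N=C(\C=C\c1ccc(Cl)cc1)c1ccc(Br)cc1` — 24700 nM

In an ADME assay on cells (Mus musculus, strain Balb/c) for cytotoxicity, read by MTT assay, with a stated time of 48 h (a lower number here means that less compound is tolerated, a higher number that more compound is tolerated), compound 3 gives 24700 nM, the second highest of the three numbers; its nearest neighbour is compound 2 with 14100 nM, and the furthest is compound 1 with 2170000 nM, a gap beyond the scatter. Going by the values given here, the only measured step is a 1.8-fold higher number from compound 2 to compound 3 (0.24 log units; within the scatter), which concerns a different change and is within the scatter.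

Compound 4 `COc1ccc(/C=C/C(=N\O)c2ccc(Br)cc2)cc1` has not yet been measured. It differs from compound 3 by methoxy in place of chloro on an aromatic carbon. Among the compounds with values here, no measured step isolates this change. What the values of compound 1 and compound 2 show is that a compound carrying methoxy on both rings gives a far higher number than one carrying chloro on both, and compound 4 carries methoxy on one ring only. A step upward in this assay beyond the scatter is therefore expected, though smaller than the gap between compound 3 and compound 1. This step is expected to be a 6.1-fold higher number from compound 3 to compound 4 (0.78 log units; beyond the scatter). Compound 4 is estimated at 150000 nM, in a range from 40000 nM to 800000 nM.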

Compound 4, half-maximal cytotoxic concentration: 23700 nM
For compound 4 the middle estimate is 6.3-fold (0.80 log units) above the measured one; the measured number lies below the stated range.
By their numbers in this assay, from the lowest: compounds 2, 4 and 3 (each within the scatter of the next); then compound 1.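

In this assay the change gives a 1.0-fold lower number from compound 3 to compound 4 (0.02 log units; within the scatter) and so leaves the number within the scatter, which means that at this position methoxy and chloro cannot be told apart. The large difference appears at the other aromatic ring, where the step gives a 92-fold lower number from compound 1 to compound 4 (1.96 log units; beyond the scatter) for bromo in place of methoxy, so methoxy at the position changed here does not by itself bring the number close to that of compound 1. Nothing shown here gives a reason for either step.

From the compounds shown here alone, it remains open whether a group of another kind, such as an amine or a carboxylic acid, would also leave the number unchanged at this position. Going by these compounds, it is also open whether chloro and methoxy would match each other on the other aromatic ring when bromo is absent.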